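The source may hold more compounds than are shown below. What is called first, only, known or untested is meant among the compounds shown, and "the series" means these compounds.

Measured compounds in the series:

compound 1, `CCC(C)n1ncn(-c2ccc(N3CCN(c4ccc(OC[C@@H]5CO[C@@](CN(C)C)(c6ccc(Cl)cc6Cl)O5)cc4)CC3)cc2)c1=O`: 1400 nM
compound 2, `CCC(C)n1ncn(-c2ccc(N3CCN(c4ccc(OC[C@@H]5CO[C@@](Cn6nc(C)nc6C)(c6ccc(Cl)cc6Cl)O5)cc4)CC3)cc2)c1=O`: 221 nM
compound 3, `CCC(C)n1ncn(-c2ccc(N3CCN(c4ccc(OC[C@@H]5CO[C@@](Cn6cnc(C)c6)(c6ccc(Cl)cc6Cl)O5)cc4)CC3)cc2)c1=O`: 102 nM

All three were run in a functional assay on HUVEC cells (Homo sapiens), read by scintillation counting and thymidine incorporation, with a stated time of 24 h; on this read-out lower numbers stand for stronger inhibition and higher numbers for weaker inhibition. Compound 1 gives the highest of the three numbers; its nearest neighbour is compound 2 at 221 nM, its furthest compound 3 at 102 nM.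

The unmeasured compound 4, `CCC(C)n1ncn(-c2ccc(N3CCN(c4ccc(OC[C@@H]5CO[C@@](Cn6cc(C)nc6C)(c6ccc(Cl)cc6Cl)O5)cc4)CC3)cc2)c1=O`, differs from compound 1 in one place: 2,4-dimethyl-1H-imidazol-1-yl in place of dimethylamino on a saturated chain carbon bound to a saturated ring carbon.

For the measured compounds named here, two measured steps bear on this change, both exchanging the dimethylamino group at the same saturated chain carbon for a five-membered aromatic ring: a 6.3-fold lower number from compound 1 to compound 2 (0.80 log units; beyond the scatter) and a 14-fold lower number from compound 1 to compound 3 (1.14 log units; beyond the scatter). Between the two rings, a 2.2-fold lower number from compound 2 to compound 3 (0.34 log units; beyond the scatter). The group entering compound 4 is closest in kind to that of compound 3, so a step of comparable size, towards a lower number, is expected in this assay.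

The expected step is an 11-fold lower number from compound 1 to compound 4 (1.03 log units; beyond the scatter). Compound 4 is therefore estimated at 130 nM, within a range of 50 nM to 400 nM.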

Compound 4, half-maximal inhibitory concentration: 492 nM
The estimate for compound 4 lay 3.8-fold (0.58 log units) below the measured number; the whole stated range lies below it.
By their numbers in this assay, from the lowest: compound 3; then compound 2; then compound 4; then compound 1.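

In this assay the ring at the saturated chain carbon proves sensitive to one small addition: methyl in place of hydrogen on an aromatic carbon costs most of the gain seen with compound 3 (a 4.8-fold higher number from compound 3 to compound 4 (0.68 log units; beyond the scatter)), while the 2,4-dimethyl-1H-imidazol-1-yl group still improves on dimethylamino (a 2.8-fold lower number from compound 1 to compound 4 (0.45 log units; beyond the scatter)). The order of the two ring types also reverses: compound 3 lies below compound 2, yet with 2,4-dimethyl-1H-imidazol-1-yl the number rises relative to the dimethyl triazolyl compound (a 2.2-fold higher number from compound 2 to compound 4 (0.35 log units; beyond the scatter)), so the imidazole ring alone does not secure the lower number. Nothing shown gives a cause for these shifts.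

Still open, as far as these compounds go, is whether the loss is specific to methyl, which an ethyl group or a chlorine in its place would test. The unsubstituted 1H-imidazol-1-yl group would also show what the remaining methyl contributes.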